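The source may hold more compounds than are shown below. What is called first, only, known or untested is meant among the compounds shown, and "the series" means these compounds.

Three compounds share one core and differ only in the acid-bearing group on an aromatic carbon. In a functional assay on CHO cells for antagonist activity at sphingosine 1-phosphate receptor 2 (Homo sapiens), read by calcium flux (on this read-out lower numbers stand for stronger inhibition and higher numbers for weaker inhibition), compound 1 `C[C@@H](C(=O)O)c1nn(Cc2cn3cc(OCC4CC4)c(Cl)cc3n2)c2ccccc2c1=O` gives 24 nM; compound 2 `COC(C(=O)O)c1nn(Cc2cn3cc(OCC4CC4)c(Cl)cc3n2)c2ccccc2c1=O` gives 23 nM; compound 3 `O=C(O)C1(c2nn(Cc3cn4cc(OCC5CC5)c(Cl)cc4n3)c3ccccc3c2=O)CC1` gives 16 nM, the lowest of the three numbers, although its steps to both others stay within the scatter. The change to compound 4 `CCC(C(=O)O)c1nn(Cc2cn3cc(OCC4CC4)c(Cl)cc3n2)c2ccccc2c1=O` is 1-carboxypropyl in place of 1-carboxycyclopropyl on an aromatic carbon. The steps of a 1.5-fold lower number from compound 1 to compound 3 (0.18 log units; within the scatter) and a 1.4-fold lower number from compound 2 to compound 3 (0.16 log units; within the scatter) also swapped one small acid-bearing group for another and stayed within the scatter, so in this assay no step beyond the scatter is expected here either. Compound 4 is therefore expected near 20 nM, between 10 nM and 40 nM. The step expected from this change is a 1.3-fold higher number from compound 3 to compound 4 (0.10 log units; within the scatter).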

Compound 4, half-maximal inhibitory concentration: 5.6 nM
Compound 4: the middle estimate sits 3.6-fold (0.55 log units) above what was measured, outside the stated range (below it).
By their numbers in this assay, from the lowest: compound 4; then compounds 3, 2 and 1 (each within the scatter of the next).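

At this position, the acid-bearing group can shift the number beyond the scatter: 1-carboxypropyl does so against 1-carboxycyclopropyl, which has the same count of heavy atoms but carries a three-membered ring (a 2.9-fold lower number from compound 3 to compound 4 (0.46 log units; beyond the scatter) in this assay). The shift also appears with ethyl in place of methoxy (a 4.1-fold lower number from compound 2 to compound 4 (0.61 log units; beyond the scatter)) and against 1-carboxyethyl (a 4.3-fold lower number from compound 1 to compound 4 (0.63 log units; beyond the scatter)). No available evidence accounts for these steps. Going by these compounds, whether a longer chain such as 1-carboxybutyl would lower the number further stays open, as does the effect of an amine in place of the carboxylic acid.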